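The source may report more compounds than this note shows. Statements on the series, on what has been measured and on what is new or still open speak of the compounds shown alone.

Compound 1, `CN(C)Cc1ccc2nc(NC(=O)NN=C(c3ccccn3)c3ccccn3)sc2c1`, and compound 2, `CCN(CC)Cc1ccc2nc(NC(=O)NN=C(c3ccccn3)c3ccccn3)sc2c1`, share one core, while compound 3, `CN(C)Cc1ccc(NC(=O)NN=C(c2ccccn2)c2ccccn2)cc1`, and compound 4, `CCN(CC)Cc1ccc(NC(=O)NN=C(c2ccccn2)c2ccccn2)cc1`, share another. How the core of compound 1 differs from the core of compound 3 is not broken down here. In a functional assay on U-937 cells (Homo sapiens) for antiproliferative activity, read by CCK-8 assay, with a stated time of 24 h (a higher number here means a weaker inhibitor, a lower number a stronger inhibitor), compound 1 gives 7800 nM. In this assay compound 2 gives 9100 nM. The change between these two, (diethylamino in place of dimethylamino on a saturated chain carbon bound to an aromatic carbon), made a step of a 1.2-fold higher number from compound 1 to compound 2 (0.07 log units; within the scatter). In this assay compound 3 reaches only a limit of the measurement, > 40000 nM. Compound 4 carries the same change on the other core, (diethylamino in place of dimethylamino on a saturated chain carbon bound to an aromatic carbon), at the same place as in the first pair. For compound 4 the expected step is a step that the limit leaves unreadable from compound 3 to compound 4, which rests on the measured pair, because a 1.2-fold higher number from compound 1 to compound 2 (0.07 log units; within the scatter) left compound 1 and compound 2 within the scatter of each other. Compound 3 sits at the limit of > 40000 nM in this assay, at which 1 of the 3 values shown sits, so the number for compound 4 is expected to lie near that limit too. The estimate for compound 4 is 50000 nM, with a range from 20000 nM to 150000 nM.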

Compound 4, half-maximal inhibitory concentration: > 40000 nM
Compound 4 ended at the assay's limit; the forecaster's own chance of this, stated with the estimate: 80%; the middle value does not contradict the limit.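

Compound 3 and compound 4 both end at a limit of this assay rather than at a number, so no step can be read between them: the limit of > 40000 nM in this assay, at which 2 of the 4 values shown sit.

The compounds shown leave open whether diethylamino in place of dimethylamino makes any difference on the core shared by compound 3 and compound 4.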